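Ethylsulfonylamino series: methyl added beside the linker

The source may report more compounds than this note shows. Statements on the series, on what has been measured and on what is new or still open speak of the compounds shown alone.

Measured compounds in a functional assay on Urethra with Alpha-1A adrenergic receptor (Oryctolagus cuniculus) as the target; a lower number here means a smaller maximal response, a higher number a larger maximal response:
compound 1 `CS(=O)(=O)Nc1ccc(F)c2c1CCCC2c1c[nH]cn1` gives 64%
compound 2 `CC(C)S(=O)(=O)Nc1cccc2c1CCCC2c1c[nH]cn1` gives 74%
compound 3 `CCS(=O)(=O)Nc1cccc(Cc2c[nH]cn2)c1` gives 80%

Compound 3 stands with its number within the scatter of compound 2, so the two cannot be told apart on this assay, while compound 1 sits beyond the scatter below compound 3. Within the data shown here, no pair among the three differs in a single place, so no step between measured compounds is available to lean on.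

Compound 4 `CCS(=O)(=O)Nc1cccc(Cc2c[nH]cn2)c1C` is the next compound in line. It differs from compound 3 as follows: methyl in place of hydrogen on an aromatic carbon. This is the smallest kind of addition, and the three measured numbers give no guide to what such a change does here.

Among the measured compounds shown here, with no comparable step on record, the step from compound 3 to compound 4 is expected to stay within the usual scatter, with no preferred direction: a number 5 percentage points lower from compound 3 to compound 4 (within the scatter). On these data alone, compound 4 is therefore estimated at 75%, with a range from 55% to 95%, the width reflecting that the effect of a methyl at this place is untested.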

Compound 4, largest response reached (reported as efficacy), in percent of the reference or control that the assay uses: 69%
The estimate for compound 4 lay 6 percentage points above the measured number, within the range that was stated.
By their numbers in this assay, from the lowest: compounds 1, 4, 2 and 3 (each within the scatter of the next, the first and the last beyond it).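

In this assay, among these compounds, this is the first step that changes one place only: methyl in place of hydrogen on an aromatic carbon, ortho to a (1H-imidazol-4-yl)methyl group and ortho to a (ethylsulfonyl)amino group, gives a number 11 percentage points lower from compound 3 to compound 4 (beyond the scatter) as a modest change. The position is therefore not neutral for the maximal response, even though the addition is a single carbon. No measurement at hand bears on the reason for this step.

Still open, on these data alone, is whether an ethyl, methoxy or chloro group on the same aromatic carbon would give a step of similar size or direction. Also open, as far as these compounds go, is whether the same methyl change behaves alike with another sulfonyl chain, such as isopropyl, on the (ethylsulfonyl)amino group's place.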